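From 4-chlorophenyl to 3-chlorophenyl on the shared core

The source may report more compounds than this note shows. Statements on the series, on what has been measured and on what is new or still open speak of the compounds shown alone.

Two compounds on a shared core have so far gone into a functional assay on T98G cells (Homo sapiens) for inhibition, read by MTT assay, with a stated time of 72 h (on this read-out higher numbers stand for weaker inhibition and lower numbers for stronger inhibition), and only one of them has yielded a number. Compound 1 `CCNC(=O)NC1CC(C)(C)Oc2ccc(Cl)cc21` stands as "not determined" (no result reported) in this record and offers no comparison. For the measured compounds named here, compound 2 `CC1(C)CC(NC(=O)Nc2ccc(Cl)cc2)c2cc(Cl)ccc2O1` gives 33000 nM as the single value available, which leaves it without a rank among measured neighbours and without a measured step to lean on. The next compound, compound 3 `CC1(C)CC(NC(=O)Nc2cccc(Cl)c2)c2cc(Cl)ccc2O1`, keeps the rest of the structure and carries 3-chlorophenyl in place of 4-chlorophenyl on an amide-type nitrogen. The two have the same atoms, joined differently. Going by the values given here, no measured pair in this assay shows what such a change does, and the data favour no direction. The only anchor for an expectation is compound 2 (33000 nM). The expected change is a 1.1-fold lower number from compound 2 to compound 3 (0.04 log units; within the scatter) and it is estimated to stay within the usual scatter of repeated measurements. For compound 3 the estimated value is 30000 nM with an expected range (from 12000 nM to 70000 nM).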

Compound 3, half-maximal inhibitory concentration: 25000 nM
The estimate for compound 3 lay 1.2-fold (0.08 log units) above the measured number, within the range that was stated.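

For the compounds shown here, the step supplies the first measured comparison at this place, on an amide-type nitrogen whose other neighbour is the carbonyl carbon. In this assay, exchanging 4-chlorophenyl for 3-chlorophenyl gives a 1.3-fold lower number from compound 2 to compound 3 (0.12 log units; within the scatter), so compounds 2 and 3 cannot be told apart on this read-out, even though the same atoms are joined differently. Going by these compounds alone, this single pair shows only that this one exchange on the shared core leaves no difference beyond the usual scatter, and nothing in hand explains that outcome or says how the read-out responds at this position.

As far as these compounds go, whether any other group on this nitrogen would separate from compounds 2 and 3 remains open, for example a phenyl ring bearing an amine or a carboxylic acid, or a longer carbon chain in place of the aromatic ring. Compound 1 stands at "not determined" (no result reported), so it gives no number against which to compare a group on this nitrogen that lacks the chlorophenyl ring.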